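This account rests on a few compounds, and the source may have more. Where it says the series, first, only, none or still open, it means among the compounds named here.

Measured so far in a functional assay on NUGC-3 cells (Homo sapiens) for antiproliferative activity, read by sulforhodamine B assay; a higher number here means a weaker inhibitor of growth, a lower number a stronger inhibitor of growth:
Compound 1 `COc1cccc(OCCC(C)(C)C)c1C(=O)/C=C/c1ccc(O)cc1`: > 30000 nM
Compound 2 `CC(C)(C)CCOc1cccc(O)c1C(=O)/C=C/c1ccc(C(=O)O)cc1`: 5440 nM
Compound 3 `CC(C)=CCOc1cccc(O)c1C(=O)/C=C/c1ccc(O)cc1`: > 30000 nM

Compound 3 gives > 30000 nM, which is a limit and not a number. Compound 1 gives > 30000 nM, which is also a limit. The small set is thus marked by the limit of > 30000 nM in this assay, at which 2 of the 3 values shown sit. Only compound 2 yields an actual number, 5440 nM.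

The next compound is compound 4 `CC(C)CCOc1cccc(O)c1C(=O)/C=C/c1ccc(O)cc1`. In it, isobutyl stands in place of 2-methylprop-1-en-1-yl on a saturated chain carbon bound to an oxygen on an aromatic ring: isobutyl in place of 2-methylprop-1-en-1-yl on a saturated chain carbon bound to an oxygen on an aromatic ring. Going by the values given here, no measured pair shows this change on its own. A step no larger than the usual scatter is therefore expected in this assay, with no preferred direction, and compound 4 may well be reported only as a limit. The expected step is a number no higher from compound 3 to compound 4 (the limit leaves the size open). The estimated value for compound 4 is 30000 nM. The estimated range for compound 4 runs from 12000 nM to 60000 nM.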

Compound 4, concentration for 50% growth inhibition: 12400 nM
Estimate against measurement, compound 4: 2.4-fold (0.38 log units) above, within the range that was stated.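

In this assay, isobutyl in place of 2-methylprop-1-en-1-yl on a saturated chain carbon bound to an oxygen on an aromatic ring gives an at least 2.4-fold lower number from compound 3 to compound 4 (0.38 log units; beyond the scatter). Going by these compounds alone, this is the first change in one place that can be read in the set, and it shows that removing the double bond from this chain alone is enough to turn a limit into a measured number. How large the step really is stays open, since compound 3 stands only at a limit: the limit of > 30000 nM in this assay, at which 2 of the 4 values shown sit.

Going by these compounds, whether an amine or a cyclohexyl ring at the end of this chain would lower the number further remains open. Compound 1 and compound 2 differ from compound 4 in more than one place, so they cannot separate the effect of the chain from that of the other groups.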